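Nitro to Hydrogen on the Benzoyl Group

The compounds below may be only part of what the source reports. "The series", "measured", "known", "first", "only" and "open" are said of these compounds alone.

Compounds measured in a functional assay on CCRF-CEM cells (Homo sapiens) for cytotoxicity, read by MTT assay, with a stated time of 96 h; on this read-out higher numbers stand for an effect only at larger amounts of compound and lower numbers for an effect already at smaller amounts:
compound 1, `COc1ccc(-c2[nH]c3ccc(OC)cc3c2/C=C(\C#N)S(=O)(=O)c2ccccc2)cc1`, gives 300 nM
compound 2, `CC(=O)/C(=C/c1c(-c2ccccc2)[nH]c2ccccc12)C(=O)c1ccccc1`, gives 8100 nM
compound 3, `CCOC(=O)/C(=C/c1c(-c2ccccc2)[nH]c2ccccc12)C(=O)c1ccc([N+](=O)[O-])cc1`, gives 1800 nM

Among these three numbers compound 3 stands second highest; compound 2 lies nearest, with a number beyond the scatter above it, and compound 1 furthest, with a number beyond the scatter below it. Compound 4 is `CCOC(=O)/C(=C/c1c(-c2ccccc2)[nH]c2ccccc12)C(=O)c1ccccc1`. It differs from compound 3 in one place: hydrogen in place of nitro on an aromatic carbon, para to a large group. For the measured compounds named here, no measured pair shows this same change, so its effect in this assay is not known from the data. The three numbers only show that the ester of compound 3 and the ketone of compound 2 spread over a range beyond the scatter. Compound 4 is therefore expected to give about 3000 nM, within 1000 nM to 9000 nM, a step of a 1.7-fold higher number from compound 3 to compound 4 (0.22 log units; within the scatter) that is estimated to lie near or just beyond the scatter toward a higher number.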

Compound 4, half-maximal effective concentration: 8000 nM
For compound 4 the middle estimate is 2.7-fold (0.43 log units) below the measured one, within the range that was stated.
By their numbers in this assay, from the lowest: compound 1; then compound 3; then compounds 4 and 2 (each within the scatter of the next).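

In this assay the step at this position reads a 4.4-fold higher number from compound 3 to compound 4 (0.65 log units; beyond the scatter) and so shows that the change from 4-nitrophenyl to phenyl counts here. For the compounds shown here, compound 4 also gives the first direct comparison of the ester with the ketone, which reads a 1.0-fold lower number from compound 2 to compound 4 (0.01 log units; within the scatter) and places ethoxy in place of methyl on a carbonyl carbon within the scatter. Nothing measured here offers a reason for the nitro step.

From the compounds shown here alone, whether an amine or a chlorine on the same aromatic carbon would match nitro remains open. So does whether nitro has the same effect when methyl replaces ethoxy on the carbonyl carbon.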